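A Carboxamide in Place of a Pyrimidine Ring

This account rests on a few compounds, and the source may have more. Where it says the series, first, only, none or still open, it means among the compounds named here.

Of the compounds shown here, three have been tested in an assay on isolated protein for inhibition of 11-beta-hydroxysteroid dehydrogenase type 2 (Mus musculus); a lower number here means a stronger inhibitor, a higher number a weaker inhibitor. Compound 1 `Cn1c(-c2ccc(-c3cncnc3)cc2)nnc1C1(c2ccc(Cl)cc2)CCC1` gives only a limit there, > 4000 nM. Compound 2 `Cn1c(-c2ccc(C(N)=O)cc2C(N)=O)nnc1C1(c2ccc(Cl)cc2)CCC1` likewise reaches only the limit of > 4000 nM. Compound 3 `Cn1c(-c2ccc(-c3cnccn3)cc2F)nnc1C1(c2ccc(Cl)cc2)CCC1` stops at the limit as well, > 4000 nM. All three rest at the limit of > 4000 nM in this assay, at which 3 of the 3 values shown sit, so no order among them can be drawn. Compound 4 `CCNC(=O)c1ccc(-c2nnc(C3(c4ccc(Cl)cc4)CCC3)n2C)cc1` is not yet measured; it carries ethylcarbamoyl in place of pyrimidin-5-yl on an aromatic carbon, para to a large group. Going by the values given here, no measured step covers this change, and compound 2, which also bears carboxamide groups, shows only a limit. Compound 4 is expected to stay weak, the step that the limit leaves unreadable from compound 1 to compound 4 amounting to nothing beyond the scatter. The estimate for compound 4 is 8000 nM, within 2000 nM to 40000 nM.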

Compound 4, half-maximal inhibitory concentration: > 4000 nM
Compound 4: no number, only a limit; the forecaster's own chance of this, stated with the estimate: 75%; the middle value does not contradict the limit.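

In this assay, going by these compounds alone, compound 4 gives only a limit, > 4000 nM, and compound 1 gives only a limit too, so no step between them can be read: the limit of > 4000 nM in this assay, at which 4 of the 4 values shown sit.

The compounds shown leave open how ethylcarbamoyl and pyrimidin-5-yl compare, and what any of these compounds' actual strength is.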